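This account rests on a few compounds, and the source may have more. Where it says the series, first, only, none or still open, it means among the compounds named here.

Measured so far in an assay on isolated protein for inhibition of myosin-2 (Bos taurus), read by spectrophotometry, with a stated time of 24 min; a higher number here means a weaker inhibitor, a lower number a stronger inhibitor:
compound 1 `CCCCCC/N=C(\C)c1c(O)c2ccccc2oc1=O` gives 2900 nM
compound 2 `CCCCC/N=C(\C)c1c(O)c2cc([N+](=O)[O-])ccc2oc1=O` gives >= 100000 nM
compound 3 `CCC/N=C(\C)c1c(O)c2ccccc2[nH]c1=O` gives >= 100000 nM

Among the compounds with values here, compound 1 is the only member of the series with a number in this assay. The value for compound 2 is a limit of the assay, not a number. The value for compound 3 is likewise only a limit. Two of the three values therefore rest at the limit of >= 100000 nM in this assay, at which 2 of the 3 values shown sit.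

Compound 4 `C/C(=N\Cc1cccnc1)c1c(O)c2ccccc2oc1=O` differs from compound 1 in one place: pyridin-3-yl in place of pentyl on a saturated chain carbon bound to a double-bonded nitrogen. Within the data shown here, no measured pair isolates this change, so its size is not known. The expected step from compound 1 to compound 4 in this assay is a 2.8-fold higher number from compound 1 to compound 4 (0.44 log units; beyond the scatter), a moderate move toward weaker inhibition, probably just beyond the usual scatter. For compound 4 the estimated value in this assay is 8000 nM, with a range from 1500 nM to 40000 nM.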

Compound 4, half-maximal inhibitory concentration: 17000 nM
Compound 4: middle estimate off by 2.1-fold (0.33 log units), on the low side, within the range that was stated.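

With the core of compound 1 held fixed, hexyl can give way to (pyridin-3-yl)methyl and a measurable number remains: in this assay the change gives a 5.9-fold higher number from compound 1 to compound 4 (0.77 log units; beyond the scatter), a modest loss. This position therefore accepts a six-membered aromatic ring with a hetero atom, and compound 4 stays a number rather than reaching the limit of the assay. Nothing shown gives a cause for this step. Open, as far as these compounds go, is whether the loss follows the ring or its nitrogen, which a benzyl group on the same carbon would separate. An octyl chain would show whether lengthening the chain beyond hexyl lowers the number further.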